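The compounds below may be only part of what the source reports. "The series", "measured", "known", "first", "only" and "open" are said of these compounds alone.

Measured compounds:
- compound 1, `O=c1[nH]nc(NCc2ccccc2)c2ccccc12`: in an assay for inhibition of casein kinase I isoform alpha (Sus scrofa), read by scintillation counting and 33P incorporation, with a stated time of 30 min, in the presence of a further agent that is not named here (on this read-out lower numbers stand for stronger inhibition and higher numbers for weaker inhibition), compound 1 gives > 10000 nM, a limit of the assay rather than a number.
- compound 2, `CCCCCC(=O)Nc1n[nH]c(=O)c2ccccc12`: in this assay compound 2 gives > 10000 nM, again a limit and not a number.

Compound 2 therefore stands at the limit of > 10000 nM in this assay, at which 2 of the 2 values shown sit. Among the measured compounds shown here, nothing in the two values separates compound 2 from compound 1; both simply sit at the limit, and no measured step exists between them.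

The next compound is compound 3, `O=C(Nc1n[nH]c(=O)c2ccccc12)c1ccccc1`, not yet measured in this assay. It differs from compound 2 in one place: phenyl in place of pentyl on a carbonyl carbon. The amide linkage on the shared core is kept; only the group on the carbonyl carbon changes.

For the measured compounds named here, with both measured compounds at the limit, there is no measured step from which to judge the size or direction of this change. The working expectation is that compound 3 also returns a limit in this assay, a step that the limit leaves unreadable from compound 2 to compound 3, that is, none beyond the scatter. Compound 3 is estimated at 15000 nM, with a range from 3000 nM to 60000 nM.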

Compound 3, half-maximal inhibitory concentration: > 10000 nM
Compound 3 was reported as a limit; the forecaster's own chance of this, stated with the estimate: 85%; the middle value is on the limit's open side.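

No step can be read from compound 2 to compound 3 in this assay, where phenyl replaces pentyl on a carbonyl carbon, as both compounds are reported only at a limit: the limit of > 10000 nM in this assay, at which 3 of the 3 values shown sit.

The compounds shown leave open whether any group on the shared core gives a readable number, and how such groups would rank.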